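Phenyl Anilide Against a Chlorobenzyl Amide at the Limit

The compounds below may be only part of what the source reports. "The series", "measured", "known", "first", "only" and "open" are said of these compounds alone.

Three amides share one core. Compound 1 `C=CC1=C(C(=O)NC2CCCCC2)C(c2ccc(OC)c(OC)c2)OC1` carries a cyclohexyl on the amide nitrogen, and in a functional assay on HeLa cells (Homo sapiens) for cytotoxicity, read by MTT assay, with a stated time of 24 h (on this read-out lower numbers stand for stronger inhibition and higher numbers for weaker inhibition), compound 1 gives 5540 nM. Compound 2 `C=CC1=C(C(=O)NCc2ccc(Cl)cc2)C(c2ccc(OC)c(OC)c2)OC1` carries a 4-chlorobenzyl in its place. In this assay compound 2 gives only a limit of the assay, > 100000 nM, so compound 2 stands at the weak end of what is shown (the limit of > 100000 nM in this assay, at which 1 of the 2 values shown sits). Among the compounds with values here, the one measured step, an at least 18-fold higher number from compound 1 to compound 2 (1.25 log units; beyond the scatter), is large. Compound 3 `C=CC1=C(C(=O)Nc2ccccc2)C(c2ccc(OC)c(OC)c2)OC1` differs from compound 2 by phenyl in place of 4-chlorobenzyl on an amide-type nitrogen. Within the data shown here, no measured step covers this change directly; an at least 18-fold higher number from compound 1 to compound 2 (1.25 log units; beyond the scatter) shows only that the 4-chlorobenzyl amide sits at the limit while the cyclohexyl amide gives a number. The step for compound 3 is therefore expected to be an at least 3.3-fold lower number from compound 2 to compound 3 (0.52 log units; beyond the scatter), but with wide uncertainty. Compound 3 is estimated in this assay at 30000 nM, within a range from 5000 nM to 150000 nM.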

Compound 3, half-maximal inhibitory concentration: 5030 nM
Compound 3: middle estimate off by 6.0-fold (0.78 log units), on the high side, and the stated range covers the measured number.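

In this assay the amide-type nitrogen takes phenyl as well as cyclohexyl, with a 1.1-fold lower number from compound 1 to compound 3 (0.04 log units; within the scatter) and so no order between the two. Carrying a six-membered aromatic ring of carbon only on this nitrogen therefore does not in itself go with the loss seen in compound 2, for the change to phenyl gives an at least 19-fold lower number from compound 2 to compound 3 (1.29 log units; beyond the scatter) and brings the number back from the weak end. Compound 2 alone stays at a limit of the assay: the limit of > 100000 nM in this assay, at which 1 of the 3 values shown sits.

A plain benzyl or a 4-chlorophenyl on this nitrogen would tell whether the chlorine or the longer link of 4-chlorobenzyl goes with that loss, and the compounds shown cannot separate the two. Going by these compounds, how a methoxy on the phenyl or a piperidine in place of the cyclohexyl would read also stays open.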